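Lengthening the Hydroxyl Arm on the Phenyl-Bearing Amine

This account rests on a few compounds, and the source may have more. Where it says the series, first, only, none or still open, it means among the compounds named here.

Three compounds share one core and differ only in the group on an amine nitrogen. Compound 1 `OCCCCNCc1nc2c(OCC3CCCCC3)cccc2[nH]1` carries a 4-hydroxybutyl group, compound 2 `OCCCCCNCc1nc2c(OCC3CCCCC3)cccc2[nH]1` a 5-hydroxypentyl group, and compound 3 `OCC(NCc1nc2c(OCC3CCCCC3)cccc2[nH]1)c1ccccc1` a 2-hydroxy-1-phenylethyl group. In an assay on cells for inhibition of interleukin-5 receptor subunit alpha (Mus musculus), read by WST assay, with a stated time of 48 h, tested at 30 uM, in the presence of a further agent that is not named here (a lower number here means less inhibition, a higher number more inhibition at the concentration tested (going by the name of the read-out)), compound 1 gives 44.3%, compound 2 gives 23.7%, and compound 3 gives 77.7%. The change from compound 1 to compound 2 is hydroxymethyl in place of hydroxy on a saturated chain carbon, four bonds along the chain from an amine nitrogen; it produced a number 20.6 percentage points lower from compound 1 to compound 2 (beyond the scatter). The two cores differ by 2-hydroxy-1-phenylethyl in place of 4-hydroxybutyl on an amine nitrogen; the matching step is a number 33.4 percentage points higher from compound 1 to compound 3 (beyond the scatter), and the step from the longer chain is a number 54 percentage points higher from compound 2 to compound 3 (beyond the scatter).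

Compound 4 `OCCC(NCc1nc2c(OCC3CCCCC3)cccc2[nH]1)c1ccccc1`, not yet measured, differs from compound 3 by hydroxymethyl in place of hydroxy on a saturated chain carbon, two bonds along the chain from an amine nitrogen and an aromatic carbon. This is the same kind of change as that from compound 1 to compound 2, but not the same: there it sat four bonds along the chain from an amine nitrogen, here two bonds along the chain from an amine nitrogen and an aromatic carbon. For compound 4 a drop is expected, a number 19.7 percentage points lower from compound 3 to compound 4 (beyond the scatter), in the direction of the earlier step because that step was a number 20.6 percentage points lower from compound 1 to compound 2 (beyond the scatter); one pair is a thin basis, so the span is wide. Compound 4 is expected to give 58%, between 38% and 76%.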

Compound 4, a percentage reported as inhibition, at one concentration (the size of the read-out at that concentration, not a potency): 64.7%
Beside the measured number, compound 4's estimate is 6.7 percentage points below it, within the range that was stated.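

In this assay, placing hydroxymethyl instead of hydroxy on the saturated chain carbon of compound 3 gives a number 13 percentage points lower from compound 3 to compound 4 (beyond the scatter), so the longer arm again goes with less inhibition at the concentration tested. Set beside the earlier step on the core without the phenyl group, the change runs in the same direction, and the two sizes cannot be told apart: the same change on two cores in this assay, a number 20.6 percentage points lower (beyond the scatter) from compound 1 to compound 2 and a number 13 percentage points lower (beyond the scatter) from compound 3 to compound 4, 7.6 percentage points apart, within the scatter of two such steps. This supports carrying the change across these two cores, but two pairs make no general rule for the series, and they do not show why the number falls.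

The compounds shown leave open whether the trend continues with a chain longer than the 2-hydroxyethyl arm of compound 4, or whether an amine or a carboxylic acid in place of the hydroxy group would behave the same way. Each number is also a reading at a single concentration, so how the potencies of these compounds compare remains unknown.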